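The compounds below may be only part of what the source reports. "The series", "measured", "known", "first", "only" and "open" are said of these compounds alone.

Compound 1 `C=C(F)C(=O)Nc1cc(Nc2nccc(-c3cn(C)c4ccccc34)n2)c(OC)cc1N(C)CCN(C)C` gives 3790 nM in a functional assay on HepG2 cells (Homo sapiens) for antiproliferative activity, read by MTT assay, with a stated time of 72 h; on this read-out lower numbers stand for stronger inhibition and higher numbers for weaker inhibition.
Compound 2 `C/C=C\C(=O)Nc1cc(Nc2nccc(-c3cn(C)c4ccccc34)n2)c(OC)cc1N(C)CCN(C)C` gives 6930 nM in this assay.
Compound 3 `COc1cc(N(C)CCN(C)C)c(NC(=O)/C=C\C(C)C)cc1Nc1nccc(-c2cn(C)c3ccccc23)n1` gives 4390 nM in this assay.

On these numbers compound 1 stands lowest of the three, but neither gap is decisive: the step of a 1.2-fold higher number from compound 1 to compound 3 (0.06 log units; within the scatter) and the step of a 1.8-fold higher number from compound 1 to compound 2 (0.26 log units; within the scatter) both stay within the scatter, so the three measured compounds cannot be separated with confidence.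

Compound 4 `CC/C=C\C(=O)Nc1cc(Nc2nccc(-c3cn(C)c4ccccc34)n2)c(OC)cc1N(C)CCN(C)C` has not yet been measured in this assay. It differs from compound 1 in one place: but-1-en-1-yl in place of 1-fluoroethenyl on a carbonyl carbon. Within the data shown here, two measured steps bear on this change, since both also exchange the 1-fluoroethenyl on the carbonyl carbon for an alkenyl chain: a 1.8-fold higher number from compound 1 to compound 2 (0.26 log units; within the scatter) and a 1.2-fold higher number from compound 1 to compound 3 (0.06 log units; within the scatter). The step of a 1.6-fold lower number from compound 2 to compound 3 (0.20 log units; within the scatter), which only lengthens the chain end, likewise stays within the scatter. The but-1-en-1-yl of compound 4 falls between these chains in size, so the expected step is a 1.3-fold higher number from compound 1 to compound 4 (0.12 log units; within the scatter), a small rise in the number that does not clearly exceed the scatter. Compound 4 is therefore estimated at 5000 nM, with a range from 2500 nM to 10000 nM.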

Compound 4, half-maximal inhibitory concentration: 6670 nM
The estimate for compound 4 lay 1.3-fold (0.13 log units) below the measured number; measured number inside the range.
By their numbers in this assay, from the lowest: compounds 1, 3, 4 and 2 (each within the scatter of the next).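

With but-1-en-1-yl in place of 1-fluoroethenyl on the carbonyl carbon, this assay shows a 1.8-fold higher number from compound 1 to compound 4 (0.25 log units; within the scatter), so a third fluorine-free alkenyl chain at this position also cannot be separated from the fluorinated one. Among the fluorine-free chains, the new compound adds a 1.0-fold lower number from compound 2 to compound 4 (0.02 log units; within the scatter) and a 1.5-fold higher number from compound 3 to compound 4 (0.18 log units; within the scatter), so a difference of one methyl in the chain, from either side, resolves nothing. All four compounds therefore remain within the scatter of their neighbours in the order of their numbers, and this position shows no measurable preference among these chains.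

As far as these compounds go, whether plain ethenyl without the fluorine, or a chain ending in an amine such as dimethylamino, would step beyond the scatter on this carbonyl carbon remains open. Nothing available explains why these chains read so alike.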